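Changing the Group on the Oxygen: Forecast for Compound 4

The source may hold more compounds than are shown below. What is called first, only, known or untested is meant among the compounds shown, and "the series" means these compounds.

compound 1, `Cc1nn(-c2ncnc3nc[nH]c23)c2c1C(OCc1ccc(Cl)cc1Cl)CC(=O)N2`: 243 nM
compound 2, `Cc1nn(-c2ncnc3nc[nH]c23)c2c1C(OCc1ccccc1F)CC(=O)N2`: 78 nM
compound 3, `Cc1nn(-c2ncnc3nc[nH]c23)c2c1C(OCc1ccc(C(C)C)cc1)CC(=O)N2`: 1690 nM

The three measured compounds share one core and differ only in the group carried on an oxygen on a saturated carbon. In a functional assay on HEK293 cells for agonist activity at G-protein coupled receptor 39 (Homo sapiens), read by scintillation proximity assay and inositol phosphate accumulation, with a stated time of 75 min (on this read-out lower numbers stand for an effect already at smaller amounts and higher numbers for an effect only at larger amounts of compound), compound 1 gives 243 nM, the second highest of the three numbers. Its nearest neighbour is compound 2: a 3.1-fold lower number from compound 1 to compound 2 (0.49 log units; beyond the scatter). Compound 3 lies furthest away: a 7.0-fold higher number from compound 1 to compound 3 (0.84 log units; beyond the scatter). Between those two the gap is wider still: a 22-fold higher number from compound 2 to compound 3 (1.34 log units; beyond the scatter).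

Compound 4 `Cc1nn(-c2ncnc3nc[nH]c23)c2c1C(OC(=O)c1ccc(F)cc1)CC(=O)N2` has not been measured. It differs from compound 1 in this way:

(4-fluorophenyl)carbonyl in place of 2,4-dichlorobenzyl on an oxygen on a saturated carbon

Among the measured compounds shown here, no measured step replaces the group on that oxygen with a (4-fluorophenyl)carbonyl, so the three steps bear on it only loosely: a fluorine on the ring went with a lower number in compound 2, while a 4-isopropyl went with a much higher one in compound 3. For compound 4 the step of a 1.2-fold higher number from compound 1 to compound 4 (0.09 log units; within the scatter) is therefore expected to be modest, with its direction uncertain. Compound 4 is estimated at 300 nM, with a range from 60 nM to 1500 nM.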

Compound 4, half-maximal effective concentration: 245 nM
For compound 4 the middle estimate is 1.2-fold (0.09 log units) above the measured one; the range from low to high includes it.
By their numbers in this assay, from the lowest: compound 2; then compounds 1 and 4 (each within the scatter of the next); then compound 3.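

The group on this oxygen need not be a benzyl: (4-fluorophenyl)carbonyl in place of 2,4-dichlorobenzyl gives a number that cannot be told apart from that of compound 1 (a 1.0-fold higher number from compound 1 to compound 4 (0.00 log units; within the scatter)). The new group also sits clear of both ends of the series (a 6.9-fold lower number from compound 3 to compound 4 (0.84 log units; beyond the scatter); a 3.1-fold higher number from compound 2 to compound 4 (0.50 log units; beyond the scatter)), so a ring attached through a carbonyl falls inside the span the benzyl groups already cover. Nothing in the data given explains these numbers.

Two things changed at once here, the carbonyl and the ring's substituents, and a 4-fluorobenzyl group on the same oxygen would show how much each contributes. Also open, going by these compounds, is how this oxygen would tolerate a longer chain such as 2-phenylethyl, or a ring carrying a carboxylic acid.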